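The source may report more compounds than this note shows. Statements on the series, on what has been measured and on what is new or still open speak of the compounds shown alone.

Going by the values given here, compound 1 `Cc1cccc(Cn2c(CN3CCN(C(=O)c4ccc(C(F)(F)F)cc4)CC3)nc3ccccc32)c1` is one of three compounds measured in an assay on isolated protein for inhibition of aldehyde dehydrogenase 1A1 (Homo sapiens), read by spectrophotometry, tested at 10 uM (a higher number here means more inhibition at the concentration tested (going by the name of the read-out), a lower number less inhibition), where compound 1 gives 22.9%, the lowest of the three. Compound 2 `O=C(C1CC1)N1CCN(Cc2nc3ccccc3n2Cc2ccc(C(F)(F)F)cc2)CC1` gives 37% and compound 3 `O=C(C1CC1)N1CCN(Cc2nc3ccccc3n2Cc2cccc(Cl)c2)CC1` gives 71.6% in this assay. Compound 4 `CCCC(=O)N1CCN(Cc2nc3ccccc3n2Cc2cccc(C)c2)CC1` differs from compound 1 in one place (propyl in place of 4-(trifluoromethyl)phenyl on a carbonyl carbon). Among the compounds with values here, the only single-step comparison available, a number 34.6 percentage points higher from compound 2 to compound 3 (beyond the scatter), concerns the group on the saturated chain carbon bound to the aromatic nitrogen, not the carbonyl carbon, so no measured step bears directly on this change. Compounds 2 and 3 both carry a small saturated group on the carbonyl and give higher readings than compound 1, but they also differ from compound 1 elsewhere. Compound 4 is therefore expected to show a modest rise, a number 13.1 percentage points higher from compound 1 to compound 4 (beyond the scatter), to an estimated 36% (range 15% to 60%).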

Compound 4, a percentage reported as inhibition, at one concentration (the size of the read-out at that concentration, not a potency): 79.1%
The estimate for compound 4 lay 43.1 percentage points below the measured number, outside the stated range (above it).
By their numbers in this assay, from the lowest: compound 1; then compound 2; then compounds 3 and 4 (each within the scatter of the next).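

Putting propyl in place of 4-(trifluoromethyl)phenyl on the carbonyl carbon gives a number 56.2 percentage points higher from compound 1 to compound 4 (beyond the scatter) in this assay. The earlier step concerned only the group on the saturated chain carbon bound to the aromatic nitrogen, whereas this pair shows that the group on the carbonyl carbon also changes the reading strongly. Nothing given here accounts for the rise.

From the compounds shown here alone, it remains open whether the ring or the trifluoromethyl matters more. A plain phenyl or a longer chain such as pentyl on the same carbonyl carbon would help separate these.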